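Swapping a fluorophenyl for cyclopentyl: cytotoxicity expected unchanged

The compounds below may be only part of what the source reports. "The series", "measured", "known", "first", "only" and "open" are said of these compounds alone.

Three measured compounds share one core and differ only in the group attached to the carbonyl carbon of an amide. Compound 1 is `Cc1ccc(C(=O)N2CCN(c3nc(=O)c4cc(C(F)(F)F)cc([N+](=O)[O-])c4s3)CC2)cc1`, compound 2 is `O=C(c1ccccc1Cl)N1CCN(c2nc(=O)c3cc(C(F)(F)F)cc([N+](=O)[O-])c3s2)CC1`, and compound 3 is `O=C(c1cccc(F)c1)N1CCN(c2nc(=O)c3cc(C(F)(F)F)cc([N+](=O)[O-])c3s2)CC1`. In an ADME assay on Vero cells (Chlorocebus sabaeus) for cytotoxicity, read by MTT assay, with a stated time of 72 h (a higher number here means that more compound is tolerated, a lower number that less compound is tolerated), compound 1 gives > 125000 nM, which is a limit of the assay and not a number. In this assay compound 2 gives > 125000 nM, again a limit. Compound 3 gives > 125000 nM, also a limit. Because all three sit at the limit of > 125000 nM in this assay, at which 3 of the 3 values shown sit, the steps a step that the two limits leave unreadable from compound 1 to compound 2, a step that the two limits leave unreadable from compound 1 to compound 3 and a step that the two limits leave unreadable from compound 2 to compound 3 cannot be sized; all that can be said is that none of the three groups pushed the value under the limit.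

Compound 4 is `O=C(C1CCCC1)N1CCN(c2nc(=O)c3cc(C(F)(F)F)cc([N+](=O)[O-])c3s2)CC1`. It differs from compound 3 by cyclopentyl in place of 3-fluorophenyl on a carbonyl carbon. Among the measured compounds shown here, no measured step covers a non-aromatic ring, so the expectation rests only on every measured compound having stayed at the limit. The expected step is a step that the limit leaves unreadable from compound 3 to compound 4, that is, none beyond the scatter. Compound 4 is therefore estimated at 200000 nM, with a range from 100000 nM to 500000 nM.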

Compound 4, half-maximal cytotoxic concentration: 120000 nM
The estimate for compound 4 lay 1.7-fold (0.22 log units) above the measured number, and the stated range covers the measured number.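

Compound 4 is the only compound shown with a non-aromatic ring on this carbonyl carbon, and the only one that gives a number rather than a limit in this assay. Replacing an aromatic ring with cyclopentyl gives an at least 1.0-fold lower number from compound 3 to compound 4 (0.01 log units; that floor lies within the scatter), an at least 1.0-fold lower number from compound 2 to compound 4 (0.01 log units; that floor lies within the scatter) and an at least 1.0-fold lower number from compound 1 to compound 4 (0.01 log units; that floor lies within the scatter), so none of the three steps can be told apart from the scatter. Going by these compounds, each is only a floor, and its true size remains unknown: the limit of > 125000 nM in this assay, at which 3 of the 4 values shown sit.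

On these data alone, whether an amine, a carboxylic acid or a longer chain on this carbonyl carbon would bring the number clearly under the limit stays open. Also open, as far as these compounds go, is how far past the limit compound 1, compound 2 and compound 3 truly lie, and so whether cyclopentyl differs from these aromatic groups at all.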